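Pyridine substituent change in a potassium channel inhibitor series

The compounds below may be only part of what the source reports. "The series", "measured", "known", "first", "only" and "open" are said of these compounds alone.

Measured compounds:
compound 1, `Cc1cc(-c2noc([C@H](C)NC(=O)c3cc(C(F)(F)F)nn3C)n2)ccn1`: 165 nM
compound 2, `C[C@H](NC(=O)c1cc(C(F)(F)F)nn1C)c1nc(-c2ccnc(C3CC3)c2)no1`: 16 nM

In an assay on T-REx-293 cells for inhibition of potassium channel subfamily T member 1 (Homo sapiens), read by patch clamp (a lower number here means a stronger inhibitor, a higher number a weaker inhibitor), compound 2 gives the lowest of the two numbers; its nearest neighbour, compound 1, gives 165 nM, which is a 10-fold lower number from compound 1 to compound 2 (1.01 log units; beyond the scatter). Compound 3, `C[C@H](NC(=O)c1cc(C(F)(F)F)nn1C)c1nc(-c2ccnc(C(F)(F)F)c2)no1`, has not yet been measured in this assay. It differs from compound 2 by trifluoromethyl in place of cyclopropyl on an aromatic carbon.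

For the measured compounds named here, only one measured step bears on this change, and only loosely: the replacement of methyl by cyclopropyl at the same position, which gave a 10-fold lower number from compound 1 to compound 2 (1.01 log units; beyond the scatter). Going by the values given here, that step shows the position tolerates a larger group and rewards it, but no measured pair tells how trifluoromethyl itself behaves there. Given that the new group is closer in size to cyclopropyl than to methyl, compound 3 is expected to lose some, but not all, of the gain seen for compound 2, an estimated 2.5-fold higher number from compound 2 to compound 3 (0.40 log units; beyond the scatter) in this assay. Compound 3 is therefore estimated at 40 nM, within a range of 12 nM to 140 nM.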

Compound 3, half-maximal inhibitory concentration: 40 nM
Beside the measured number, compound 3's estimate shows no gap at the digits printed; measured number inside the range.
By their numbers in this assay, from the lowest: compound 2; then compound 3; then compound 1.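

In this assay the position next to the ring nitrogen now carries a third group, and trifluoromethyl lands between the other two: it keeps part of the gain over methyl, with a 4.1-fold lower number from compound 1 to compound 3 (0.62 log units; beyond the scatter) here, but it does not reach cyclopropyl, with a 2.5-fold higher number from compound 2 to compound 3 (0.40 log units; beyond the scatter) on that side. The gain over methyl is therefore not tied to the three-membered ring, as a group with no ring also gives a lower number than methyl, while cyclopropyl still gives the lowest number of the three compounds. Both steps lie beyond the usual scatter, so the order of the three groups at this position is a real one in this assay and not an artefact of repeat measurement.

As far as these compounds go, whether an isopropyl, a methoxy group or an amine at the same position would match or pass cyclopropyl remains open, as does whether this order would hold if the rest of the molecule changed. Nothing shown accounts for why the three groups fall in this order.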